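Replacing quinolin-4-yl with pyridin-3-yl on the amide carbonyl

The source may report more compounds than this note shows. Statements on the series, on what has been measured and on what is new or still open speak of the compounds shown alone.

Compound 1 `COc1ccc(S(=O)(=O)Oc2ccccc2NC(=O)c2ccncc2)cc1` gives 55 nM in a functional assay on NCI-H460 cells (Homo sapiens) for antiproliferative activity; a higher number here means a weaker inhibitor, a lower number a stronger inhibitor. Compound 2 `COc1ccc(S(=O)(=O)Oc2ccccc2NC(=O)c2ccccn2)cc1` gives 300 nM in this assay, which is a 5.5-fold higher number from compound 1 to compound 2 (0.74 log units; beyond the scatter). For compound 3 `COc1ccc(S(=O)(=O)Oc2ccccc2NC(=O)c2ccnc3ccccc23)cc1` the this assay reports only a limit, > 10000 nM, so compound 3 stands at the limit of > 10000 nM in this assay, at which 1 of the 3 values shown sits, and no number is known for it. The change to compound 4 `COc1ccc(S(=O)(=O)Oc2ccccc2NC(=O)c2cccnc2)cc1` is pyridin-3-yl in place of quinolin-4-yl on a carbonyl carbon. Going by the values given here, the steps that bear on it run the opposite way, namely an at least 180-fold higher number from compound 1 to compound 3 (2.25 log units; beyond the scatter) and an at least 33-fold higher number from compound 2 to compound 3 (1.52 log units; beyond the scatter), both large. Undoing the quinolin-4-yl in favour of a pyridin-3-yl is therefore expected to lower the number in this assay by a large step, an at least 83-fold lower number from compound 3 to compound 4 (1.92 log units; beyond the scatter). Compound 4 is estimated at 120 nM, within a range from 30 nM to 500 nM.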

Compound 4, half-maximal inhibitory concentration: > 6000 nM
Compound 4 ended at the assay's limit (the forecaster's own chance of this, stated with the estimate: 5%); middle value at least 50-fold (1.69 log units) from the limit.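

In this assay, the place of the ring nitrogen on the amide carbonyl proves decisive: pyridin-3-yl in place of pyridin-4-yl gives an at least 100-fold higher number from compound 1 to compound 4 (2.03 log units; beyond the scatter), and pyridin-3-yl in place of pyridin-2-yl gives an at least 20-fold higher number from compound 2 to compound 4 (1.30 log units; beyond the scatter). Leaving out the carbon-only ring of quinolin-4-yl therefore does not by itself return the number to the level of compound 1 or compound 2. Compound 4 gives a limit rather than a number: the limit of > 6000 nM in this assay, at which 1 of the 4 values shown sits.

The step between compound 3 and compound 4 cannot be read. Still open, from the compounds shown here alone, is whether a pyridin-4-yl carrying an amine would keep the activity of compound 1.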